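Furan for Phenyl on an Inactive Nucleoside Scaffold

The source may report more compounds than this note shows. Statements on the series, on what has been measured and on what is new or still open speak of the compounds shown alone.

Compound 1 `Nc1nc2c(c(-c3ccccc3)cn2[C@@H]2O[C@H](CO)[C@@H](O)[C@H]2O)c(=O)[nH]1` was tested in a functional assay on HepG2 cells (Homo sapiens) for antiproliferative activity, read by XTT assay, with a stated time of 72 h; a lower number here means a stronger inhibitor, a higher number a weaker inhibitor. In this assay compound 1 gives only a limit, > 20000 nM. Compound 2 `COc1ncnc2c1c(-c1cc3ccccc3o1)cn2[C@@H]1O[C@H](CO)[C@@H](O)[C@H]1O` likewise gives only a limit in this assay, > 20000 nM. Compound 1 therefore stands at the limit of > 20000 nM in this assay, at which 2 of the 2 values shown sit, with no numerical value to anchor it. Compound 3 `Nc1nc2c(c(-c3ccco3)cn2[C@@H]2O[C@H](CO)[C@@H](O)[C@H]2O)c(=O)[nH]1` differs from compound 1 by furan-2-yl in place of phenyl on an aromatic carbon. For the measured compounds named here, with no measured step to draw on, the change is expected to bring no shift beyond the scatter, amounting to a step that the limit leaves unreadable from compound 1 to compound 3. Compound 3 is estimated at 25000 nM in this assay, within a range from 8000 nM to 80000 nM, and most likely again reported only as a limit.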

Compound 3, half-maximal inhibitory concentration: > 20000 nM
Compound 3: only a limit was reported (the forecaster's own chance of this, stated with the estimate: 85%); the middle value does not contradict the limit.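

For the compounds shown here, compound 1 and compound 3 both give only a limit in this assay, so no step from phenyl to furan-2-yl can be read between them. The compounds shown leave open which change to the shared core, if any, would bring a measurable value in this assay.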